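A few compounds are considered here, and "the series" means these few. Any claim that something is new, unique, unknown or untested is made for them only; others in the source may bear on it.

Measured so far:
Compound 1 `CCOC(=O)CCCCCOc1cccc(CN(C(=O)c2ccc(-c3ccc4ccccc4c3)cc2)C(C)C)c1` — in an ADME assay on BJ cells (Homo sapiens) for cytotoxicity, read by CellTiter-Glo and resazurin assay, with a stated time of 72 h (a higher number here means that more compound is needed for the effect, a lower number that less compound is needed), compound 1 reads > 26000 nM, which is a limit of the assay.
Compound 2 `CCOC(=O)CCCCCOc1cccc(CN(C(=O)c2ccc(-c3ccoc3)cc2)C(C)C)c1` — in this assay compound 2 reads > 26000 nM, likewise a limit.
Compound 3 `CCOC(=O)CCCCCOc1cccc(CN(C(=O)c2ccc(-c3ccco3)cc2)C(C)C)c1` — in this assay compound 3 reads > 26000 nM, again a limit.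

Compound 3 thus stands at the limit (the limit of > 26000 nM in this assay, at which 3 of the 3 values shown sit). Compound 4 `CCOC(=O)CCCCCOc1cccc(CN(C(=O)c2ccc(-c3ccc4c(c3)OCCO4)cc2)C(C)C)c1` differs from compound 3 in one place: 2,3-dihydro-1,4-benzodioxin-6-yl in place of furan-2-yl on an aromatic carbon. Among the compounds with values here, the steps that bear on this change, a step that the two limits leave unreadable from compound 1 to compound 3 and a step that the two limits leave unreadable from compound 2 to compound 3, as well as a step that the two limits leave unreadable from compound 1 to compound 2, all run between limits and give no readable size; none of the three aryl groups tried pulls the value off the limit. No direction can be read for the new group either. Compound 4 is therefore expected to sit at the limit as well, with an estimated step that the limit leaves unreadable from compound 3 to compound 4. The estimate for compound 4 is 35000 nM, within 15000 nM to 120000 nM.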

Compound 4, half-maximal effective concentration: > 24400 nM
Compound 4 was reported as a limit; the forecaster's own chance of this, stated with the estimate: 85%; the middle value is on the limit's open side.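

Within the data shown here, compound 4, like compounds 1, 2 and 3, is reported only as a limit, so no step between compound 4 and compound 1, compound 2 or compound 3 can be read. The compounds shown leave open what actual effective concentration any of them has in this assay.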